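Carbamoylmethyl for isopropyl, tried a second time on a new core

The source may report more compounds than this note shows. Statements on the series, on what has been measured and on what is new or still open speak of the compounds shown alone.

Measured so far, in a functional assay on the whole organism (Tail, strain ICR) with Mus musculus as the target, in the tail flick test, with a stated time of 30 min, at a dose of 25 umol/kg by the oral route; on this read-out lower numbers stand for a weaker effect and higher numbers for a stronger effect at the one dose given:
Compound 1 `NC(=O)CC[C@H](NC(=O)CN(c1ncnc2c1ncn2C1CCCCO1)C1CC1)C(=O)OCc1ccccc1` gives 47%.
Compound 2 `CC(C)C[C@H](NC(=O)CN(c1ncnc2c1ncn2C1CCCCO1)C1CC1)C(=O)OCc1ccccc1` gives 26.2%.
Compound 3 `CC(C)C[C@H](NC(=O)CN(c1nc(Cl)nc2[nH]cnc12)C1CC1)C(=O)O` gives 23.4%.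

Compounds 1 and 2 share one core and differ in a single place: carbamoylmethyl in place of isopropyl on a saturated chain carbon, two bonds along the chain from an amide-type nitrogen and a carbonyl carbon That change gave a step of a number 20.8 percentage points higher from compound 2 to compound 1 (beyond the scatter). Compound 3 carries a different core; the difference between the two cores is not broken down here. Compound 4 `NC(=O)CC[C@H](NC(=O)CN(c1nc(Cl)nc2[nH]cnc12)C1CC1)C(=O)O` is not yet measured and carries the same change relative to compound 3: carbamoylmethyl in place of isopropyl on a saturated chain carbon, two bonds along the chain from an amide-type nitrogen and a carbonyl carbon The place lines read alike, so the change is the same, only set on another core. The expectation rests on compound 3 with 23.4% and on the measured step of a number 20.8 percentage points higher from compound 2 to compound 1 (beyond the scatter), somewhat tempered since a single example on one core is thin support. The expected step is a number 15.6 percentage points higher from compound 3 to compound 4 (beyond the scatter). Compound 4 is therefore estimated at 39%, likely between 22% and 58%.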

Compound 4, a percentage reported as activity, at one dose (the size of the read-out at that dose, not a potency): 33.1%
Estimate against measurement, compound 4: 5.9 percentage points above; the measured number falls inside the stated range.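

In this assay, setting carbamoylmethyl in place of isopropyl on the core of compound 3 gave a number 9.7 percentage points higher from compound 3 to compound 4 (within the scatter), so on this core alone the change cannot be told apart from repeat-measurement scatter. Going by these compounds alone, the two steps cannot be told apart from each other either: the same change on two cores in this assay, a number 20.8 percentage points higher (beyond the scatter) from compound 2 to compound 1 and a number 9.7 percentage points higher (within the scatter) from compound 3 to compound 4, 11.1 percentage points apart, within the scatter of two such steps This shows that nothing so far separates the way the two cores respond, but it does not show that the change truly raises the read-out on the second core, and two pairs are too few to prove that it carries over.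

The compounds shown leave open how a carboxylic acid, an amine or a longer chain would behave in this place. They also leave open whether either core would respond to such groups as it did to carbamoylmethyl.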